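Replacing methylpiperazine with a bridged diamine

The compounds below may be only part of what the source reports. "The series", "measured", "known", "first", "only" and "open" are said of these compounds alone.

Values in an ADME assay on microsomes from liver (Homo sapiens) for metabolic stability, read by LC-MS, with a stated time of 10 min; a lower number here means that less of the compound is left, a higher number that more of the compound is left:
Compound 1 `CN(C[C@H]1Cc2c(cccc2N2CCN(C3CC3)CC2)CN1)[C@H]1CCCc2cccnc21`: 15.5%
Compound 2 `CN1CCN(c2cccc3c2C[C@H](CN(C)[C@H]2CCCc4cccnc42)NC3)CC1`: 75.8%

Compound 2 holds the higher number of the two measured compounds. Compound 3 `CN(C[C@H]1Cc2c(cccc2N2C[C@@H]3C[C@H]2CN3)CN1)[C@H]1CCCc2cccnc21` differs from it on an aromatic carbon: a group of 7 heavy atoms (5 carbon, 2 nitrogen; 2 five-membered non-aromatic rings with 1 hetero atom each) in place of a group of 7 heavy atoms (5 carbon, 2 nitrogen; one six-membered non-aromatic ring with 2 hetero atoms), on an aromatic carbon. For the measured compounds named here, only one measured step bears on this, a number 60.3 percentage points higher from compound 1 to compound 2 (beyond the scatter), large and beyond the scatter, with methyl in place of cyclopropyl on an amine nitrogen in a ring. Given that step, a moderately lower number is expected in this assay, with wide uncertainty. The estimated step is a number 13.8 percentage points lower from compound 2 to compound 3 (beyond the scatter). For compound 3 the expected value is 62%, with an estimated range of 38% to 85%.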

Compound 3, percent of the compound remaining: 100%
Compound 3: middle estimate off by 38 percentage points, on the low side; measured number above the stated range.
By their numbers in this assay, from the lowest: compound 1; then compound 2; then compound 3.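

In this assay, the change on the aromatic carbon itself moves the number: the bridged diamine in place of 4-methylpiperazin-1-yl gives a number 24.2 percentage points higher from compound 2 to compound 3 (beyond the scatter), and in place of the cyclopropyl-bearing piperazine gives a number 84.5 percentage points higher from compound 1 to compound 3 (beyond the scatter). The earlier compounds shown here varied only the substituent on a piperazine nitrogen, whereas these steps show that the piperazine ring can be replaced at this position without loss in this read-out. No measured evidence here accounts for the gain. Still open, as far as these compounds go, is whether a methyl on the free ring nitrogen of the bridged diamine, or a morpholine at the same position, would keep this number.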